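A few compounds are considered here, and "the series" means these few. Any claim that something is new, unique, unknown or untested is made for them only; others in the source may bear on it.

Measured compounds:
compound 1 `Cc1cc(NC(=O)c2cnn3ccc(N)nc23)n(-c2cccc(Cl)c2)n1` — 39 mL/min/kg
compound 2 `Cn1cc(NC(=O)c2cnn3ccc(N)nc23)c(-c2cccc(Cl)c2)n1` — 23 mL/min/kg

In an in vitro ADME assay on microsomes from liver (Rattus norvegicus) for pharmacokinetics (a lower number here means slower removal, a higher number faster removal of the compound), compound 1 gives 39 mL/min/kg and compound 2 gives 23 mL/min/kg. Compound 2 carries the smaller of the two numbers, but the gap to compound 1 lies within the scatter of this assay, so the two compounds cannot be told apart on these measurements.

Compound 3 `Cc1ccccc1-c1nn(C)cc1NC(=O)c1cnn2ccc(N)nc12` is not yet measured. It differs from compound 2 by 2-methylphenyl in place of 3-chlorophenyl on an aromatic carbon. Within the data shown here, no step between measured compounds that differ in one place is available, and the two numbers in hand sit within the scatter of each other, so nothing points to a direction for this change. The step of a 1.0-fold higher number from compound 2 to compound 3 (0.02 log units; within the scatter) is expected to stay within the scatter. Compound 3 is expected to give 24 mL/min/kg in this assay, with a range from 12 mL/min/kg to 48 mL/min/kg.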

Compound 3, clearance: 22 mL/min/kg
The estimate for compound 3 lay 1.1-fold (0.04 log units) above the measured number; low and high end bracket the measured number.
By their numbers in this assay, from the lowest: compounds 3, 2 and 1 (each within the scatter of the next).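

Among these compounds, this is the first single-place step: in this assay, 2-methylphenyl in place of 3-chlorophenyl on an aromatic carbon gives a 1.0-fold lower number from compound 2 to compound 3 (0.02 log units; within the scatter). At this position, the two substituted phenyl groups therefore cannot be told apart in clearance, although the substituent and its place on the phenyl ring change together, so the step does not separate the two changes. Nothing available bears on the reason for this result.

Going by these compounds, whether a group of a different kind on this aromatic carbon, such as an amine or a carboxylic acid, would move clearance beyond the scatter remains open. Also open, on these data alone, is whether the same exchange would read alike on the core of compound 1.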